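Removing a Methoxy Group from a Pyridine Ring

A few compounds are considered here, and "the series" means these few. Any claim that something is new, unique, unknown or untested is made for them only; others in the source may bear on it.

Among the measured compounds shown here, compound 2 (`COc1cncc(C2=CC3CNCC(C2)C3)c1`) gives 0.3 nM in an in vitro assay on SH-EP1 cells for displacement of a labelled ligand from Neuronal acetylcholine receptor; alpha4/beta2 (Homo sapiens) (on this read-out lower numbers stand for stronger inhibition and higher numbers for weaker inhibition), the lowest of the two numbers measured so far. Compound 1 (`Clc1ccc(C2=CC3CNCC(C2)C3)cn1`) gives 0.4 nM in this assay, which lies within the scatter of compound 2. Compound 3 (`C1=C(c2cccnc2)CC2CNCC1C2`) differs from compound 2 by hydrogen in place of methoxy on an aromatic carbon. For the measured compounds named here, no measured pair shows this change, so its effect here is unknown. A small step toward a weaker number is expected, a 3.3-fold higher number from compound 2 to compound 3 (0.52 log units; beyond the scatter), roughly at the edge of the scatter. Compound 3 is estimated at 1 nM in this assay, between 0.3 nM and 3 nM.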

Compound 3, inhibition constant: 0.2 nM
Beside the measured number, compound 3's estimate is 5.0-fold (0.70 log units) above it; measured number outside the range, below it.
By their numbers in this assay, from the lowest: compounds 3, 2 and 1 (each within the scatter of the next).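

At the carbon two atoms from the ring nitrogen, hydrogen in place of methoxy gives a 1.5-fold lower number from compound 2 to compound 3 (0.18 log units; within the scatter) in this assay and so costs nothing measurable. Hydrogen in place of chloro gives a 2.0-fold lower number from compound 1 to compound 3 (0.30 log units; within the scatter) as well, so neither group is needed for a number this low on this series. Nothing here explains why these changes leave the number in place.

Going by these compounds, whether an amine or a carboxylic acid at this carbon would also keep the number remains open. The same goes for a longer chain, such as butoxy, in place of methoxy.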